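Bromo for methyl on a sulfonyl aryl ring

The source may hold more compounds than are shown below. What is called first, only, known or untested is meant among the compounds shown, and "the series" means these compounds.

Compound 1 `CN1C/C(=C\c2ccc(C(F)(F)F)cc2)C(=O)/C(=C/c2cccnc2)C1`: 4830 nM
Compound 2 `CN1C/C(=C\c2ccc(C#N)cc2)C(=O)/C(=C/c2cccnc2)C1`: 13600 nM
Compound 3 `Cc1ccc(S(=O)(=O)N2C/C(=C\c3cccnc3)C(=O)/C(=C/c3ccccc3F)C2)cc1`: 10300 nM

These values come from a functional assay on SMMC-7721 cells (Homo sapiens) for cytotoxicity, read by MTT assay, with a stated time of 24 h; on this read-out higher numbers stand for weaker inhibition and lower numbers for stronger inhibition. Compound 3, at 10300 nM, lies within the scatter of compound 2, while compound 1 shows a lower number, beyond the scatter. Compound 4 `O=C1/C(=C/c2cccnc2)CN(S(=O)(=O)c2ccc(Br)cc2)C/C1=C\c1ccccc1F` carries bromo in place of methyl on an aromatic carbon. Among the compounds with values here, the only measured step, a 2.8-fold higher number from compound 1 to compound 2 (0.45 log units; beyond the scatter), is modest, but it exchanges other groups on a different compound pair, so it bears only loosely on this change. No step beyond the scatter is therefore expected in this assay. The expected step is a 1.3-fold lower number from compound 3 to compound 4 (0.11 log units; within the scatter). Compound 4 is estimated at 8000 nM, with an expected range of 3500 nM to 18000 nM.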

Compound 4, half-maximal inhibitory concentration: 9100 nM
Compound 4: the middle estimate sits 1.1-fold (0.06 log units) below what was measured; the range from low to high includes it.
By their numbers in this assay, from the lowest: compounds 1, 4, 3 and 2 (each within the scatter of the next, the first and the last beyond it).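

In this assay, within the data shown here, going from (4-methylphenyl)sulfonyl to (4-bromophenyl)sulfonyl gives a 1.1-fold lower number from compound 3 to compound 4 (0.05 log units; within the scatter), the first reading at this position, since no earlier pair differed here. Bromo and methyl, on this aromatic carbon para to a large group, are therefore not told apart by this assay on this scaffold. No measurement in hand offers an explanation for this result. The compounds shown leave open whether an amine or a carboxylic acid on this same carbon would give a step beyond the scatter.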